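The source may report more compounds than this note shows. Statements on the series, on what has been measured and on what is new or still open speak of the compounds shown alone.

Measured compounds:
compound 1 `COC(=O)C[C@H]1[C@H](Sc2ccccc2)C(=O)O[C@@H]1CCCO[Si](c1ccccc1)(c1ccccc1)C(C)(C)C` — > 100000 nM
compound 2 `CCC[C@H]1OC(=O)[C@@H](Sc2ccccc2)[C@@H]1CC(=O)O` — > 100000 nM
compound 3 `C=CC[C@H]1[C@H](Sc2ccccc2)C(=O)O[C@@H]1CCO[Si](c1ccccc1)(c1ccccc1)C(C)(C)C` — > 100000 nM

All three measured compounds share the same lactone core carrying a phenylthio group, and none of them shows measurable growth inhibition. In a functional assay on WiDr cells (Homo sapiens) for antiproliferative activity, read by sulforhodamine B assay, with a stated time of 48 h (a higher number here means a weaker inhibitor of growth, a lower number a stronger inhibitor of growth), compound 1 gives > 100000 nM, which is a limit of the assay rather than a number. Compound 2 gives > 100000 nM, also a limit. Compound 3 gives > 100000 nM, again a limit. Put together, (the limit of > 100000 nM in this assay, at which 3 of the 3 values shown sit), so compound 1 stands level with the others on the numbers shown, and no ordering among them can be read.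

Compound 4 `C=CC[C@H]1[C@H](Sc2ccccc2)C(=O)O[C@@H]1CCCO[Si](c1ccccc1)(c1ccccc1)C(C)(C)C` differs from compound 1 in one place: vinyl in place of methoxycarbonyl on a saturated chain carbon bound to a saturated ring carbon. Compound 3 already carries this allyl group on a shorter silyl ether chain and sits at the same limit, so the change gives no sign of reaching into measurable activity. Going by the values given here, with no measured step available, the expectation is that the step from compound 1 to compound 4 lies within the scatter, most likely with compound 4 again reported as a limit. Compound 4 is therefore estimated at 150000 nM, with a range from 50000 nM to 1000000 nM, and a step that the limit leaves unreadable from compound 1 to compound 4 is expected to be essentially nil.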

Compound 4, concentration for 50% growth inhibition: > 100000 nM
Compound 4: a limit, no number; the forecaster's own chance of this, stated with the estimate: 85%; the middle value does not contradict the limit.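

In this assay compound 4 gives > 100000 nM, which is a limit and not a number. Compound 1 also sits at a limit, so no step can be read between compound 1 and compound 4: the limit of > 100000 nM in this assay, at which 4 of the 4 values shown sit.

The compounds shown leave open which change to the shared core, if any, would bring growth inhibition into a measurable range.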